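Amine headgroup swap at the chain end: compound 4

A few compounds are considered here, and "the series" means these few. Any claim that something is new, unique, unknown or untested is made for them only; others in the source may bear on it.

All four compounds share one core and differ only in the amine at the end of the propoxy chain. Compound 1 `COc1cc2c(Nc3ccc(C#N)cc3)ncnc2cc1OCCCN(C)C` carries a dimethylamino group, compound 2 `COc1cc2c(Nc3ccc(C#N)cc3)ncnc2cc1OCCCN1CCC(O)CC1` a 4-hydroxypiperidin-1-yl group, compound 3 `COc1cc2c(Nc3ccc(C#N)cc3)ncnc2cc1OCCCN1CCC(CO)CC1` a 4-(hydroxymethyl)piperidin-1-yl group, and the unmeasured compound 4 `COc1cc2c(Nc3ccc(C#N)cc3)ncnc2cc1OCCCN1CCc2ccccc2C1` a 1,2,3,4-tetrahydroisoquinolin-2-yl group.

In a functional assay on SH-SY5Y cells (Homo sapiens) for antiproliferative activity, read by MTT assay, with a stated time of 72 h (on this read-out lower numbers stand for stronger inhibition and higher numbers for weaker inhibition), compound 1 gives 34900 nM. For compound 2 the read-out is a limit of the assay, > 100000 nM. Compound 3 gives 21600 nM, the lowest of the two numbers shown; the step of a 1.6-fold lower number from compound 1 to compound 3 (0.21 log units; within the scatter) separates it from compound 1, so no order between those two can be claimed. The other steps are an at least 2.8-fold higher number from compound 1 to compound 2 (0.45 log units; beyond the scatter) and an at least 4.6-fold lower number from compound 2 to compound 3 (0.66 log units; beyond the scatter), the latter resting on (the limit of > 100000 nM in this assay, at which 1 of the 3 values shown sits).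

The change from compound 3 to compound 4 is 1,2,3,4-tetrahydroisoquinolin-2-yl in place of 4-(hydroxymethyl)piperidin-1-yl on a saturated chain carbon, three bonds along the chain from an oxygen on an aromatic ring. Among the measured compounds shown here, no measured step removes the hydroxyl-bearing group in favour of a fused aromatic ring; the amine swaps seen so far move the number only modestly or stay within the scatter. On that basis a step of a 1.4-fold lower number from compound 3 to compound 4 (0.16 log units; within the scatter) is expected in this assay, that is no step beyond the scatter. For compound 4 the estimate is therefore 15000 nM, expected to lie between 4000 nM and 60000 nM.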

Compound 4, half-maximal inhibitory concentration: > 100000 nM
Compound 4: a limit, no number (the forecaster's own chance of this, stated with the estimate: 10%); middle value at least 6.6-fold (0.82 log units) from the limit.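

In this assay, 1,2,3,4-tetrahydroisoquinolin-2-yl on this saturated chain carbon gives an at least 4.6-fold higher number from compound 3 to compound 4 (0.66 log units; beyond the scatter), and in place of dimethylamino it gives an at least 2.8-fold higher number from compound 1 to compound 4 (0.45 log units; beyond the scatter). The read-out of compound 4 is a limit, which makes it the second compound after compound 2 to give one, so a limit at this chain end is not confined to a hydroxyl-bearing piperidine: compound 4 has no hydrogen-bond donor in the entering group, while the 4-(hydroxymethyl)piperidin-1-yl group of compound 3 has one and still gives a number. The step from compound 2 to compound 4 cannot be read, and the two compounds cannot be ordered, as both values are limits: the limit of > 100000 nM in this assay, at which 2 of the 4 values shown sit.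

From the compounds shown here alone, it remains open whether the step to compound 4 follows the fused benzene ring or the loss of the hydroxyl, and a plain piperidin-1-yl or a morpholin-4-yl group on the same chain carbon would help to separate the two. Also open, going by these compounds, is whether these amine effects hold on a longer chain, for instance a butoxy chain ending in 4-(hydroxymethyl)piperidin-1-yl.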